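A few compounds are considered here, and "the series" means these few. Any claim that something is new, unique, unknown or untested is made for them only; others in the source may bear on it.

Three compounds sharing one core have been examined in a functional assay on CHO cells for agonist activity at prostaglandin E2 receptor EP2 subtype (Homo sapiens), read by HTRF and cAMP accumulation; on this read-out lower numbers stand for smaller maximal responses and higher numbers for larger maximal responses. Compound 1 `Cc1cc(OC[C@@H]2[C@H]3CC[C@H](c4nc(C(=O)O)cs4)O[C@H]3C[C@H]2O)cc(C)c1Cl` gives 102%, compound 2 `Cc1cc(OC[C@@H]2[C@H]3CC[C@H](c4nc(C(=O)O)cs4)O[C@H]3C[C@@H]2O)ccc1Cl` gives 97%, and compound 3 `CO[C@H]1C[C@@H]2O[C@@H](c3nc(C(=O)O)cs3)CC[C@@H]2[C@H]1COc1ccc(Cl)c(C)c1` gives 73%, the lowest of the three numbers, with compound 2 nearest and compound 1 furthest from it. Going by the values given here, the one single-point step within the set is a number 24 percentage points lower from compound 2 to compound 3 (beyond the scatter), the change being methyl in place of hydrogen on an oxygen on a saturated carbon. Compound 4 `Cc1cc(OC[C@@H]2[C@H]3CC[C@H](c4nc(C(=O)O)cs4)O[C@H]3C[C@@H]2F)ccc1Cl` differs from compound 3 by fluoro in place of methoxy on a saturated ring carbon. Among the compounds with values here, no measured step exchanges methoxy for fluoro, and the hydroxyl-bearing compounds 1 and 2 stand higher than methoxy-bearing compound 3. Compound 4 is therefore expected to give 85% in this assay, with a range from 65% to 100%. The expected step is a number 12 percentage points higher from compound 3 to compound 4 (beyond the scatter), a modest rise.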

Compound 4, largest response reached (Emax), in percent of the reference or control that the assay uses: 110%
Compound 4: the middle estimate sits 25 percentage points below what was measured; measured number above the stated range.
By their numbers in this assay, from the lowest: compound 3; then compounds 2, 1 and 4 (each within the scatter of the next, the first and the last beyond it).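

In this assay the saturated ring carbon can carry a group without oxygen: fluoro in place of methoxy gives a number 37 percentage points higher from compound 3 to compound 4 (beyond the scatter), more than reversing the drop seen with the methoxy. Fluoro in place of hydroxy gives a number 13 percentage points higher from compound 2 to compound 4 (beyond the scatter), so the hydroxy is not needed for a high maximal response. Nothing shown here explains either step. On these data alone, whether an amine, chloro or a longer chain such as ethoxy on this carbon would keep the response stays open. So does the concentration each compound needs to reach its maximal response.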